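Swapping the benzylic aryl group on compound 1's core

The source may hold more compounds than are shown below. What is called first, only, known or untested is meant among the compounds shown, and "the series" means these compounds.

Compound 1 `CCc1ccccc1N(Cc1nnc(Cc2ccc(Cl)cc2)o1)S(=O)(=O)c1ccc(C)cc1` sits in the middle of the three measured compounds: in an assay on CHO cells for displacement of a labelled ligand from prostaglandin E2 receptor EP1 subtype (Homo sapiens) (on this read-out lower numbers stand for stronger inhibition and higher numbers for weaker inhibition), compound 1 gives 398 nM, close to compound 3 `Cc1ccc(S(=O)(=O)N(Cc2nnc(Cc3ccccc3F)o2)c2cccc(Cl)c2C)cc1` with 501 nM, while compound 2 `Cc1ccc(S(=O)(=O)N(Cc2nnc(Cc3ccc(N(C)C)cc3)o2)c2cccc(Cl)c2C)cc1` with 12.6 nM stands well apart. Compound 4 `CCc1ccccc1N(Cc1nnc(COc2ccc(OC)cc2)o1)S(=O)(=O)c1ccc(C)cc1` differs from compound 1 by 4-methoxyphenoxy in place of 4-chlorophenyl on a saturated chain carbon bound to an aromatic carbon. For the measured compounds named here, the only measured step touching this place is a 40-fold higher number from compound 2 to compound 3 (1.60 log units; beyond the scatter), which shows that the group on the saturated chain carbon bound to the aromatic carbon can move this assay strongly. Compound 4 replaces a halogen-bearing ring with an oxygen-linked ring carrying methoxy, so a somewhat lower number is expected, with wide uncertainty: the expected step is a 2.0-fold lower number from compound 1 to compound 4 (0.30 log units; within the scatter), giving an estimate for compound 4 of 200 nM, between 40 nM and 1000 nM.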

Compound 4, half-maximal inhibitory concentration: 25.1 nM
Estimate against measurement, compound 4: 8.0-fold (0.90 log units) above; measured number outside the range, below it.
By their numbers in this assay, from the lowest: compounds 2 and 4 (each within the scatter of the next); then compounds 1 and 3 (each within the scatter of the next).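

On the core of compound 1, this position turns out to matter in this assay: moving from 4-chlorophenyl to 4-methoxyphenoxy gives a 16-fold lower number from compound 1 to compound 4 (1.20 log units; beyond the scatter) and so a large gain. The earlier step at this place showed only a loss, and on a different core, so a strong move toward lower numbers on this core is new. The change alters both the link and the ring substituent at once, and a single step cannot divide its effect between them.

A 4-chlorophenoxy or 4-methoxybenzyl group on the same core would separate the two. Nothing given here accounts for the size of the step.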